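The compounds below may be only part of what the source reports. "The series", "measured", "known", "first", "only" and "open" are said of these compounds alone.

Series notes. Compound 1 `COC(=O)c1cc(-c2cnc(C(=O)CCc3ccc(-c4ccccc4)cc3)o2)ccn1` and compound 2 `O=C(O)c1cc(-c2cnc(C(=O)CCc3ccc(-c4ccccc4)cc3)o2)ccn1` share one core, while compound 3 `O=C(O)c1ccc(-c2cnc(CCCc3ccc(-c4ccccc4)cc3)o2)nc1` and compound 4 `COC(=O)c1ccc(-c2cnc(CCCc3ccc(-c4ccccc4)cc3)o2)nc1` share another. In an assay for inhibition of Fatty-acid amide hydrolase 1 (Rattus norvegicus) (a lower number here means a stronger inhibitor, a higher number a weaker inhibitor), compound 1 gives 1.5 nM, and compound 2 gives 50 nM. The change between them, (methyl in place of hydrogen on an oxygen next to a carbonyl group), produced a 33-fold lower number from compound 2 to compound 1 (1.52 log units; beyond the scatter). In this assay compound 3 gives 20000 nM, the highest number of the three measured. The difference between the core of compound 3 and the core of compound 2 is not broken down here, so that pair is compared only through their values. Compound 4 has not been measured. It differs from compound 3 by methyl in place of hydrogen on an oxygen next to a carbonyl group, the same change as that from compound 2 to compound 1, made at the same place but on the other core. For the measured compounds named here, the step in this assay is expected at a 13-fold lower number from compound 3 to compound 4 (1.12 log units; beyond the scatter), resting on the single measured pair, because a 33-fold lower number from compound 2 to compound 1 (1.52 log units; beyond the scatter) was observed on the other core. Going by the values given here, as only one such pair exists and the cores differ, a wider spread is allowed. Compound 4 is estimated at 1500 nM in this assay, with a range from 250 nM to 8000 nM.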

Compound 4, inhibition constant: 50000 nM
Beside the measured number, compound 4's estimate is 33-fold (1.52 log units) below it; measured number outside the range, above it.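

In this assay, carboxy to methoxycarbonyl gives a 2.5-fold higher number from compound 3 to compound 4 (0.40 log units; beyond the scatter). The change therefore does not carry over between these two cores, in either size or direction: the same change on two cores in this assay, a 33-fold lower number (1.52 log units; beyond the scatter) from compound 2 to compound 1 and a 2.5-fold higher number (0.40 log units; beyond the scatter) from compound 3 to compound 4, 83-fold (1.92 log units) apart, beyond the scatter of two such steps

This rests on a single pair on each core, and the difference between the cores is not broken down, so nothing here assigns the reversal to any one part of that difference or shows how the change would behave on a third core.

Still open, on these data alone, is how the step would read between cores that differ in one place only, for example a core that keeps the chain carbonyl of compound 1 but carries the 5-carboxypyridin-2-yl group of compound 3. Also open, as far as these compounds go, is whether an ethyl ester or a primary amide in place of the methoxycarbonyl group would follow the step seen on the core of compound 1, the step seen on the core of compound 3, or neither.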